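Amine substituent variation on the shared core

The source may hold more compounds than are shown below. What is called first, only, known or untested is meant among the compounds shown, and "the series" means these compounds.

Measured so far:
Compound 1 `Cc1ccc(NC2=CC(=O)c3nc4n(c3C2=O)[C@H]2OC[C@@H](O)[C@H]2OC4)cc1`: 3860 nM
Compound 2 `CCOc1ccc(NC2=CC(=O)c3c(nc4n3[C@H]3OC[C@@H](O)[C@H]3OC4)C2=O)cc1`: 14400 nM
Compound 3 `O=C1C=C(Nc2cccc(Cl)c2)C(=O)c2c1nc1n2[C@H]2OC[C@@H](O)[C@H]2OC1`: 6040 nM

In a functional assay on HeLa cells (Homo sapiens) for inhibition, read by sulforhodamine B assay (on this read-out higher numbers stand for weaker inhibition and lower numbers for stronger inhibition), compound 2 stands highest of the three numbers, and its gaps to compound 3 and to compound 1 both lie beyond the scatter, so compound 2 is the weakest inhibitor among the measured compounds. Compound 1 and compound 3 sit within the scatter of each other: a 1.6-fold higher number from compound 1 to compound 3 (0.19 log units; within the scatter).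

Compound 4 `O=C1C(NCc2ccccc2)=CC(=O)c2c1nc1n2[C@H]2OC[C@@H](O)[C@H]2OC1` differs from compound 2 in one place: benzyl in place of 4-ethoxyphenyl on an amine nitrogen. For the measured compounds named here, the only measured step exchanges one aryl group for another on the same amine nitrogen and did not move the number beyond the scatter. Going by the values given here, no measured step replaces an aryl group with a benzyl group, so nothing in the set bears directly on this change, and its direction is open. The expectation is therefore no step beyond the scatter, held with little confidence: a 1.6-fold lower number from compound 2 to compound 4 (0.20 log units; within the scatter). Compound 4 is estimated at 9000 nM, with a wide range from 2500 nM to 35000 nM.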

Compound 4, half-maximal inhibitory concentration: 11000 nM
For compound 4 the middle estimate is 1.2-fold (0.09 log units) below the measured one; the measured number falls inside the stated range.
By their numbers in this assay, from the lowest: compounds 1, 3, 4 and 2 (each within the scatter of the next, the first and the last beyond it).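

In this assay, benzyl in place of 4-ethoxyphenyl on an amine nitrogen gives a 1.3-fold lower number from compound 2 to compound 4 (0.12 log units; within the scatter), so this exchange does not move the number beyond the scatter. For the compounds shown here, the earlier step covered only one aryl group for another, whereas this one puts a benzyl group on the same nitrogen and also drops the hydrogen-bond acceptor counted in 4-ethoxyphenyl, again with no shift beyond the scatter. No supporting measurement bears on why the number holds at this position.

As far as these compounds go, whether a phenethyl group, with its longer chain, or a cyclohexyl group, with no aromatic ring, would keep the number within the scatter remains open. Also open, from the compounds shown here alone, is how a chlorine or ethoxy group on the benzyl ring would read in this assay.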